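This account rests on a few compounds, and the source may have more. Where it says the series, first, only, none or still open, it means among the compounds named here.

Compound 1 `O=C1COc2ccc(-c3[nH]c(-c4c[nH]c5ncccc45)nc3-c3ccccc3)cc2N1` was examined in a functional assay on DLD-1 cells (Homo sapiens) for cytotoxicity, read by colorimetric assay and MTT assay, with a stated time of 3 days, tested at 1 uM (a higher number here means a weaker effect of the compound at the concentration tested, a lower number a stronger effect), and in that test compound 1 gives 97.7%. Compound 2 `O=C1COc2ccc(-c3nn(-c4ccc(F)cc4)cc3-c3ccccc3)cc2N1` was examined in the same way, and in this assay compound 2 gives 64.4%. Among these two numbers compound 1 stands highest; the only other number, that of compound 2, lies lower by a gap beyond the usual scatter. For the measured compounds named here, compound 1 and compound 2 differ from each other in more than one place, so their two values are simply set side by side and no single step between them is drawn.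

Compound 3 `O=C1COc2ccc(-c3[nH]c(-c4ccc(F)cc4)nc3-c3ccccc3)cc2N1` has not been measured. It differs from compound 1 by the change (a group of 7 heavy atoms (6 carbon, 1 fluorine; one six-membered aromatic ring of carbon only) in place of a group of 9 heavy atoms (7 carbon, 2 nitrogen; one five-membered aromatic ring with 1 hetero atom, one six-membered aromatic ring with 1 hetero atom), on an aromatic carbon). Since compound 2 also carries a 4-fluorophenyl and in this assay compound 2 gives 64.4%, the step of a number 17.7 percentage points lower from compound 1 to compound 3 (beyond the scatter) is expected to run downward, probably beyond the scatter, though the mixed outcome of compound 2 leaves the size uncertain. For compound 3 the expected value in this assay is 80%, with a range from 55% to 100%.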

Compound 3, a percentage reported as activity, at one concentration (the size of the read-out at that concentration, not a potency): 94.8%
The estimate for compound 3 lay 14.8 percentage points below the measured number, and the stated range covers the measured number.
By their numbers in this assay, from the lowest: compound 2; then compounds 3 and 1 (each within the scatter of the next).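

At this carbon, which lies between two ring nitrogen atoms, the change to 4-fluorophenyl in this assay gives a number 2.9 percentage points lower from compound 1 to compound 3 (within the scatter) and so leaves the reading within the scatter, even though the group that leaves has two rings, one hydrogen-bond donor and one hydrogen-bond acceptor and the group that enters has one ring and neither donor nor acceptor. Within this pair, then, neither the second ring nor that donor and acceptor is needed to keep the reading where it stands, and the presence of a 4-fluorophenyl group does not by itself bring the reading to that of compound 2 at 64.4% in this comparison. Nothing at hand bears on why the two groups read alike.

The compounds shown leave open whether a group of another kind at this carbon, such as an aminomethyl group, a carboxylic acid or a plain methyl, would shift the reading beyond the scatter. They also leave open whether the flat outcome of this change would hold at any other concentration, since compound 1 and compound 3 are each shown at a single one.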